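The source may hold more compounds than are shown below. What is called first, only, known or untested is meant among the compounds shown, and "the series" means these compounds.

In an ADME assay for permeability, using PAMPA, with a stated time of 4 h, tested at 10 uM (on this read-out lower numbers stand for lower permeability and higher numbers for higher permeability), compound 1 `O=C(CCCCN1CCCCC1)Nc1cc(-c2ccncc2)n[nH]1`, with pyridin-4-yl on the shared core, gives 2 10^-6 cm/s. Compound 2 `O=C(CCCCN1CCCCC1)Nc1cc(-c2ccc(Cl)cc2)n[nH]1`, with 4-chlorophenyl, gives > 10 10^-6 cm/s, which is a limit of the assay and not a number. Compound 3 `COc1cccc(-c2cc(NC(=O)CCCCN3CCCCC3)[nH]n2)c1`, with 3-methoxyphenyl, gives > 10 10^-6 cm/s, which is also a limit. Compound 2 therefore stands with one other compound at the limit of > 10 10^-6 cm/s in this assay, at which 2 of the 3 values shown sit. The measured changes are an at least 5.0-fold higher number from compound 1 to compound 2 (0.69 log units; beyond the scatter) and an at least 5.0-fold higher number from compound 1 to compound 3 (0.69 log units; beyond the scatter), while the last comparison is a step that the two limits leave unreadable from compound 2 to compound 3.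

Compound 4 `O=C(CCCCN1CCCCC1)Nc1cc(-c2ccc(C(F)(F)F)cc2)n[nH]1` has trifluoromethyl in place of chloro on an aromatic carbon. For the measured compounds named here, no measured step makes this exchange. The nearest guide is the replacement of pyridin-4-yl, where compound 2 shows an at least 5.0-fold higher number from compound 1 to compound 2 (0.69 log units; beyond the scatter) and compound 3 shows an at least 5.0-fold higher number from compound 1 to compound 3 (0.69 log units; beyond the scatter). Compound 4 keeps the phenyl ring of compound 2, so no step beyond the scatter is expected, and the reading may well be a limit again. The expected size is a step that the limit leaves unreadable from compound 2 to compound 4. Compound 4 is estimated at 14 10^-6 cm/s, within an expected range of 8 10^-6 cm/s to 28 10^-6 cm/s.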

Compound 4, apparent permeability: > 10 10^-6 cm/s
Compound 4 was reported as a limit; the forecaster's own chance of this, stated with the estimate: 70%; the middle value does not contradict the limit.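

In this assay compound 4 gives > 10 10^-6 cm/s, which is a limit and not a number. For the compounds shown here, compound 2 also stands at a limit, so no step between compound 2 and compound 4 can be read. The compounds shown leave open whether trifluoromethyl and chloro differ on this read-out at all.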